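A Hydroxylated Chain on the Amine of Compound 2

The source may report more compounds than this note shows. Statements on the series, on what has been measured and on what is new or still open speak of the compounds shown alone.

Measured so far:
compound 2, `CCCNc1cc(Oc2ccc(NC(=O)Nc3cccc(C(F)(F)F)c3)cc2)ncn1`, 32 nM
compound 3, `CNc1nccc(Oc2ccc(NC(=O)Nc3cccc(C(F)(F)F)c3)cc2)n1`, 50 nM
compound 1, `O=C(Nc1ccc(Oc2ccncn2)cc1)Nc1cccc(C(F)(F)F)c1`, 160 nM

In an assay on isolated protein for inhibition of serine/threonine-protein kinase TNNI3K (Homo sapiens) (a higher number here means a weaker inhibitor, a lower number a stronger inhibitor), compound 2 holds the lowest of the three numbers. Its nearest neighbour is compound 3, and a 1.6-fold higher number from compound 2 to compound 3 (0.19 log units; within the scatter) lies within the scatter, so the two cannot be ranked. Compound 1 stands furthest away, and a 5.0-fold lower number from compound 1 to compound 2 (0.70 log units; beyond the scatter) is a modest but real step.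

Compound 4 is `CC(C)(O)CNc1cc(Oc2ccc(NC(=O)Nc3cccc(C(F)(F)F)c3)cc2)ncn1`. Its difference from compound 2 is 1-hydroxy-1-methylethyl in place of ethyl on a saturated chain carbon bound to a nitrogen on an aromatic ring. The measured steps that touch the amine are a 5.0-fold lower number from compound 1 to compound 2 (0.70 log units; beyond the scatter) and a 3.2-fold lower number from compound 1 to compound 3 (0.51 log units; beyond the scatter), both gains from attaching an alkylamino group, and a 1.6-fold higher number from compound 2 to compound 3 (0.19 log units; within the scatter), which shows that altering that alkyl group changed little. For the measured compounds named here, none of the measured steps adds a hydroxyl group, so there is no direct precedent for this change. With that in mind, compound 4 is expected to stay close to compound 2, with a 1.1-fold higher number from compound 2 to compound 4 (0.04 log units; within the scatter) as the anticipated step and no shift beyond the scatter. The estimate for compound 4 in this assay is 35 nM, within a range of 12 nM to 100 nM.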

Compound 4, half-maximal inhibitory concentration: 40 nM
The estimate for compound 4 lay 1.1-fold (0.06 log units) below the measured number; low and high end bracket the measured number.
By their numbers in this assay, from the lowest: compounds 2, 4 and 3 (each within the scatter of the next); then compound 1.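

In this assay, replacing propyl with 2-hydroxy-2-methylpropyl gives a 1.3-fold higher number from compound 2 to compound 4 (0.10 log units; within the scatter), so a larger, branched chain carrying a hydroxyl group can sit on this amine without a change that can be read. The gain over the core without an amine also holds, with a 4.0-fold lower number from compound 1 to compound 4 (0.60 log units; beyond the scatter). For the compounds shown here, this position therefore accepts a group with a hydrogen-bond donor and a hydrogen-bond acceptor, which the ethyl it replaces does not have, and this is something the simple alkyl chains of the earlier compounds could not show.

Nothing measured here bears on why the number stays put when the hydroxyl group enters. As far as these compounds go, it also remains open whether a carboxylic acid or an amine at the end of the chain, or a longer chain, would be accepted in the same way.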